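The source may report more compounds than this note shows. Statements on the series, on what has been measured and on what is new or still open speak of the compounds shown alone.

Working notes on the series. Within the data shown here, compound 2 `O=C(/C=C/c1cn(-c2ccccc2)nc1-c1ccncc1)c1ccsc1` is the lower of the two numbers so far in a functional assay on HCT-116 cells (Homo sapiens) for inhibition, read by sulforhodamine B assay, with a stated time of 72 h; a lower number here means a stronger inhibitor, a higher number a weaker inhibitor: compound 2 gives 1100 nM, while compound 1 `O=C(/C=C/c1cn(-c2ccccc2)nc1-c1cccnc1)c1cc[nH]c1` gives 7400 nM in this assay. Compound 1 and compound 2 differ in two places, so no single step is drawn between them; their two values simply stand as shown. The next compound, compound 3 `O=C(/C=C/c1cn(-c2ccccc2)nc1-c1ccncc1)c1cc[nH]c1`, is reached from compound 2 by a single change: 1H-pyrrol-3-yl in place of thiophen-3-yl on a carbonyl carbon. Compound 3 thus carries the same carbonyl-side ring as compound 1 on the core of compound 2. Among the measured compounds shown here, nothing measured here isolates this change on its own, so the direction rests on the two values shown, with compound 1 at 7400 nM the only guide. A weakening step of a 2.7-fold higher number from compound 2 to compound 3 (0.44 log units; beyond the scatter) is expected for compound 3 in this assay. Compound 3 is estimated at 3000 nM, within 1000 nM to 9000 nM.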

Compound 3, half-maximal inhibitory concentration: 15700 nM
Compound 3: the middle estimate sits 5.2-fold (0.72 log units) below what was measured, outside the stated range (above it).
By their numbers in this assay, from the lowest: compound 2; then compound 1; then compound 3.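

The carbonyl position is sensitive to the choice of five-membered ring: 1H-pyrrol-3-yl in place of thiophen-3-yl gives a 14-fold higher number from compound 2 to compound 3 (1.15 log units; beyond the scatter) in this assay, a large step and the first single change read at this carbon. The aromatic carbon bearing the pyridine ring also gets its first reading: with 1H-pyrrol-3-yl held constant, pyridin-4-yl in place of pyridin-3-yl gives a 2.1-fold higher number from compound 1 to compound 3 (0.33 log units; beyond the scatter), a modest step but still beyond the scatter. No measurement here accounts for either step.

From the compounds shown here alone, whether thiophen-3-yl gives a similarly large advantage when pyridin-3-yl is present remains open. Also open is how furan-3-yl or 1-methyl-1H-pyrrol-3-yl on the same carbonyl carbon would compare with the two rings shown.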